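Moving the methoxy group of compound 3

The source may report more compounds than this note shows. Statements on the series, on what has been measured and on what is new or still open speak of the compounds shown alone.

Compound 1 `Nn1c(SCc2ccccc2)nnc1-c1c[nH]c2ccccc12` gives 2300 nM
Compound 2 `Nn1c(SCc2ccc([N+](=O)[O-])cc2)nnc1-c1c[nH]c2ccccc12` gives 250 nM
Compound 3 `COc1cccc(CSc2nnc(-c3c[nH]c4ccccc34)n2N)c1` gives 1730 nM

In a functional assay on HeLa cells (Homo sapiens) for cytotoxicity, read by MTT assay, with a stated time of 72 h (on this read-out higher numbers stand for weaker inhibition and lower numbers for stronger inhibition), compound 3 gives 1730 nM and compound 1 gives 2300 nM within the scatter of each other, while compound 2 gives a much lower 250 nM on the same scale. Compound 4 `COc1ccc(CSc2nnc(-c3c[nH]c4ccccc34)n2N)cc1` has the same atoms as compound 3, joined differently (4-methoxyphenyl in place of 3-methoxyphenyl on a saturated chain carbon bound to a sulfur). For the measured compounds named here, two measured steps bear on this change. Methoxy in place of hydrogen gave a 1.3-fold lower number from compound 1 to compound 3 (0.12 log units; within the scatter) within the scatter, whereas nitro in place of hydrogen gave a 9.2-fold lower number from compound 1 to compound 2 (0.96 log units; beyond the scatter) beyond it. Going by the values given here, only the methoxy step involves the group that moves here, and no measured pair compares two placings of one group, so no step beyond the scatter is expected. The expected step runs a 1.2-fold lower number from compound 3 to compound 4 (0.06 log units; within the scatter) by this estimate. Compound 4 is expected at 1500 nM with an estimated range of 600 nM to 3500 nM in this assay.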

Compound 4, half-maximal inhibitory concentration: 750 nM
For compound 4 the middle estimate is 2.0-fold (0.30 log units) above the measured one; the measured number falls inside the stated range.
By their numbers in this assay, from the lowest: compound 2; then compound 4; then compounds 3 and 1 (each within the scatter of the next).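

Where the methoxy sits turns out to matter: 4-methoxyphenyl in place of 3-methoxyphenyl gives a 2.3-fold lower number from compound 3 to compound 4 (0.36 log units; beyond the scatter), so a group that made little difference in one placing makes a clear one in the other. Compared with hydrogen, this placing gives a 3.1-fold lower number from compound 1 to compound 4 (0.49 log units; beyond the scatter), though methoxy in place of nitro still gives a 3.0-fold higher number from compound 2 to compound 4 (0.48 log units; beyond the scatter). Nothing available explains why the placing changes the number.

Going by these compounds, how an amine or a carboxylic acid would read in place of the methoxy of compound 4 remains open. So does whether groups other than methoxy also respond to a change of placing.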